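Removing a methoxy group from two related cores

The compounds below may be only part of what the source reports. "The series", "measured", "known", "first", "only" and "open" are said of these compounds alone.

Four compounds were compared in a functional assay on HeLa cells (Homo sapiens) for antiproliferative activity, read by MTT assay, with a stated time of 72 h; a lower number here means a stronger inhibitor, a higher number a weaker inhibitor. Compound 2 `COc1ccc2oc(CSC(=S)N3CCCCC3)cc(=O)c2c1` gives 11900 nM. Compound 1 `O=c1cc(CSC(=S)N2CCCCC2)oc2ccccc12` differs from it by hydrogen in place of methoxy on an aromatic carbon. For compound 1 the reported value, > 25000 nM, is a limit of the assay rather than a number: the limit of > 25000 nM in this assay, at which 1 of the 3 values shown sits. The step of an at least 2.1-fold higher number from compound 2 to compound 1 (0.32 log units; beyond the scatter) is therefore counted only from that limit. Compound 3 `COc1ccc2occ(CSC(=S)N3CCCCC3)c(=O)c2c1` has the same atoms as compound 2 joined differently; the difference between the two cores is not broken down here. In this assay compound 3 gives 3500 nM. Compound 4 `O=c1c(CSC(=S)N2CCCCC2)coc2ccccc12` differs from compound 3 by hydrogen in place of methoxy on an aromatic carbon, the same change seen between compound 2 and compound 1. Given the measured step of an at least 2.1-fold higher number from compound 2 to compound 1 (0.32 log units; beyond the scatter), the same kind of change is expected to give a 2.6-fold higher number from compound 3 to compound 4 (0.41 log units; beyond the scatter). Compound 4 is estimated at 9000 nM, most likely between 4000 nM and 25000 nM.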

Compound 4, half-maximal inhibitory concentration: 2300 nM
Compound 4: the middle estimate sits 3.9-fold (0.59 log units) above what was measured; the whole stated range lies above it.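

On the core of compound 3, putting hydrogen in place of methoxy gives a 1.5-fold lower number from compound 3 to compound 4 (0.18 log units; within the scatter), so the change leaves no clear mark on this core. Set beside the earlier step, the same change does not carry over unaltered from one core to the other: the same change on two cores in this assay, an at least 2.1-fold higher number (0.32 log units; beyond the scatter) from compound 2 to compound 1 and a 1.5-fold lower number (0.18 log units; within the scatter) from compound 3 to compound 4, at least 3.1-fold (0.50 log units) apart, beyond the scatter of two such steps. On these data alone, the value of compound 1, > 25000 nM, is a limit of the assay and not a number, so the full size of the earlier step stays unknown, and two cores cannot show why the steps differ or how the change would behave on a third core.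

The compounds shown leave open how each core would respond to other groups at the same place on the aromatic ring, such as a longer chain like ethoxy, a hydroxyl or an amine.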